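A few compounds are considered here, and "the series" means these few. Any claim that something is new, unique, unknown or untested is made for them only; others in the source may bear on it.

Measured in a functional assay on MOLT-4 cells (Homo sapiens) for antiproliferative activity; on this read-out higher numbers stand for weaker inhibition and lower numbers for stronger inhibition:
- compound 1 `COc1cc(C(=O)c2sc(-c3ccncc3)cc2N)cc(OC)c1OC` gives 88 nM
- compound 2 `COc1cc(C(=O)c2sc(-c3ccc(F)cc3)cc2N)cc(OC)c1OC` gives 12 nM

Compound 2 holds the lower of the two numbers and is the stronger inhibitor of this pair. The next compound to consider is compound 3 `COc1cc(C(=O)c2sc(-c3ccc(C(F)(F)F)cc3)cc2N)cc(OC)c1OC`, which differs from compound 2 as follows: trifluoromethyl in place of fluoro on an aromatic carbon. Trifluoromethyl stands in place of fluoro on an aromatic carbon, para to a large group.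

Going by the values given here, only one measured step bears on this change, and only indirectly: a 7.3-fold lower number from compound 1 to compound 2 (0.87 log units; beyond the scatter). It is modest but beyond the scatter, and it exchanges pyridin-4-yl for 4-fluorophenyl. Among the compounds with values here, no measured compound carries trifluoromethyl, and the data do not show the effect of replacing fluoro alone. The step from 4-fluorophenyl to 4-(trifluoromethyl)phenyl keeps the phenyl ring, so a smaller move than a 7.3-fold lower number from compound 1 to compound 2 (0.87 log units; beyond the scatter) is expected, although this rests on a single step. A slightly higher number is the expected direction, and a result within the scatter would not be surprising. The estimated step is a 2.1-fold higher number from compound 2 to compound 3 (0.32 log units; beyond the scatter) in this assay. For compound 3 the expected value is 25 nM, with an estimated range from 7 nM to 100 nM.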

Compound 3, half-maximal inhibitory concentration: 250 nM
Beside the measured number, compound 3's estimate is 10-fold (1.00 log units) below it; the measured number lies above the stated range.
By their numbers in this assay, from the lowest: compound 2; then compound 1; then compound 3.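

In this assay, this position on the six-membered aromatic ring of carbon only proves highly sensitive to the group placed there: trifluoromethyl in place of fluoro gives a 21-fold higher number from compound 2 to compound 3 (1.32 log units; beyond the scatter) as a large step, although the change adds only a few heavy atoms and no hydrogen-bond donors or acceptors. Keeping a phenyl ring is therefore not enough to retain the low number, and the earlier advantage of 4-fluorophenyl over pyridin-4-yl does not carry over to every phenyl group, since 4-(trifluoromethyl)phenyl gives a 2.8-fold higher number from compound 1 to compound 3 (0.45 log units; beyond the scatter) as a modest step beyond the scatter. No supporting measurement on these compounds accounts for the loss seen with trifluoromethyl.

As far as these compounds go, with only fluoro and trifluoromethyl compared on the phenyl ring, these two points define no trend, so it remains open whether chloro, methyl or methoxy at the same place would stay close to compound 2 or fall toward compound 3. Also open, from the compounds shown here alone, is how the unsubstituted phenyl group or an amine at this place would compare.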